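The source may report more compounds than this note shows. Statements on the series, on what has been measured and on what is new or still open speak of the compounds shown alone.

Three compounds sharing the same acyl part have been run in a functional assay on the whole organism for inhibition, with Brassica napus as the target, with a stated time of 72 h, tested at 100 mg/L; a higher number here means more inhibition of growth at the concentration tested, a lower number less inhibition of growth. Compound 3 `COc1cc(OC)nc(NC(=S)NC(=O)c2c(-c3ccc(Cl)cc3Cl)noc2C)n1` gives 70.8%, and compound 1 `COc1cc(Cl)nc(NC(=S)NC(=O)c2c(-c3ccc(Cl)cc3Cl)noc2C)n1` gives 61%. One change separates them, (chloro in place of methoxy on an aromatic carbon), and the step is a number 9.8 percentage points lower from compound 3 to compound 1 (within the scatter). Compound 2 `COc1cc(OC)n2s/c(=N\C(=O)c3c(-c4ccc(Cl)cc4Cl)noc3C)nc2n1` carries another core; how that core differs from the core of compound 3 is not broken down here. In this assay compound 2 gives 85.6%. Compound 4 `COc1cc(Cl)nc2n/c(=N/C(=O)c3c(-c4ccc(Cl)cc4Cl)noc3C)sn12` is not yet measured and differs from compound 2 by chloro in place of methoxy on an aromatic carbon, the same kind of change, here at a place meta to a fused ring and para to a fused ring rather than meta to a large group. Resting on the earlier step of a number 9.8 percentage points lower from compound 3 to compound 1 (within the scatter), the expected step is a number 8.6 percentage points lower from compound 2 to compound 4 (within the scatter). Compound 4 is therefore estimated at 77%, between 63% and 90%.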

Compound 4, percent growth inhibition at one concentration: 70.8%
For compound 4 the middle estimate is 6.2 percentage points above the measured one; measured number inside the range.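

In this assay, chloro in place of methoxy on an aromatic carbon gives a number 14.8 percentage points lower from compound 2 to compound 4 (beyond the scatter), and the two steps on the two cores do not differ: the same change on two cores in this assay, a number 9.8 percentage points lower (within the scatter) from compound 3 to compound 1 and a number 14.8 percentage points lower (beyond the scatter) from compound 2 to compound 4, 5 percentage points apart, within the scatter of two such steps Within this series, the step carries from one core to the other in direction and, within the scatter, in size, even though only the new step lies beyond the scatter on its own. Two cores and a single kind of change do not show that it would carry to further cores or explain why the number falls.

The compounds shown leave open how an amine, a methyl group or a longer alkoxy chain in that place would compare with methoxy and chloro. From the compounds shown here alone, the acyl part is the same in all four compounds, so the effect of changing it also remains open.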